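Cyclobutylmethoxy in Place of Ethylsulfanyl: Compound 4 Expected

The source may hold more compounds than are shown below. What is called first, only, known or untested is meant among the compounds shown, and "the series" means these compounds.

In an assay on membranes from HeLa cells for displacement of a labelled ligand from adenosine receptor A3 (Homo sapiens), read by scintillation counting, with a stated time of 180 min, tested at 1 uM (a higher number here means more inhibition at the concentration tested (going by the name of the read-out), a lower number less inhibition), the three measured compounds give:
compound 1 `CCSC(=O)C1=C(C)NC(=O)NC1c1cccs1` gives 1%
compound 2 `CCSC(=O)C1=C(C)NC(=O)NC1c1ccsc1` gives 2%
compound 3 `CC1=C(c2ncc(C)o2)C(c2ccsc2)NC(=O)N1` gives 2%

Compound 2 stands level with compound 3 at the digits shown, the two together the highest of three numbers, and from compound 1 to compound 2 the step is a number 1 percentage points higher from compound 1 to compound 2 (within the scatter). Compound 4 `CC1=C(C(=O)OCC2CCC2)C(c2ccsc2)NC(=O)N1` differs from compound 2 by cyclobutylmethoxy in place of ethylsulfanyl on a carbonyl carbon. For the measured compounds named here, no measured step exchanges only that group; the closest is no change at the digits printed from compound 2 to compound 3 (within the scatter), where the entire (ethylsulfanyl)carbonyl was swapped with no change. With every measured number low and every step within scatter, compound 4 is expected to show a number 1 percentage points higher from compound 2 to compound 4 (within the scatter). The estimate for compound 4 is 3%, ranging from 0% to 14%.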

Compound 4, a percentage reported as inhibition, at one concentration (the size of the read-out at that concentration, not a potency): 2%
The estimate for compound 4 lay 1 percentage points above the measured number; measured number inside the range.
By their numbers in this assay, from the lowest: compounds 1, 2, 3 and 4 (each within the scatter of the next).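

For the compounds shown here, the step that exchanges only this group, cyclobutylmethoxy in place of ethylsulfanyl on a carbonyl carbon, shows no change at the digits printed from compound 2 to compound 4 (within the scatter). The carbonyl stays in place here, and the entering group brings a four-membered non-aromatic ring of carbon only, yet the number stays within the scatter of compound 2. Nothing available explains this result.

Going by these compounds, whether an amide or a carboxylic acid at this carbonyl carbon, or a longer chain on its oxygen, would read differently remains open.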